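The source may hold more compounds than are shown below. What is called first, only, known or untested is meant among the compounds shown, and "the series" means these compounds.

Compound 1 `CC[C@H](C1CC1)n1c(=O)c(C)nc2c(-c3cc(F)c(OC)cc3Cl)ccnc21` is one of three compounds tested in a functional assay for antagonist activity at corticotropin-releasing factor receptor 1 (Rattus norvegicus); on this read-out lower numbers stand for stronger inhibition and higher numbers for weaker inhibition. In this assay compound 1 gives 1.7 nM, the lowest number of the three. Compound 3 `COCC(C1CC1)n1c(=O)c(C)nc2c(-c3cc(F)c(OC)cc3Cl)ncnc21` gives 7.5 nM in this assay, and compound 2 `CC[C@H](C1CC1)n1c(=O)c(C)nc2c(-c3ccc(Cl)cc3Cl)ccnc21` gives 8.2 nM, so both sit well above compound 1, each of these gaps lying beyond the usual scatter. On these numbers compound 1 is the most potent of the three.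

Compound 4 `CC[C@H](C1CC1)n1c(=O)c(C)nc2c(-c3cc(F)c(OC)cc3C)ccnc21` has not yet been measured. It differs from compound 1 in a single spot: methyl in place of chloro on an aromatic carbon. In words, a methyl takes the place of a chloro on an aromatic carbon, while the rest of the molecule, including the shared core, is unchanged.

Among the compounds with values here, no pair of measured compounds shows this exact swap, so there is no measured step to lean on. Chloro and methyl are each a single heavy atom, neither carries a charge, and neither adds a hydrogen-bond donor or acceptor, so the change is small. The step from compound 1 to compound 4 is expected to be modest, a 2.1-fold higher number from compound 1 to compound 4 (0.31 log units; beyond the scatter), most likely a slight rise in the number, and it may well stay within the scatter. Compound 4 is therefore expected to give about 3.5 nM in this assay, with a likely range from 1.2 nM to 10 nM.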

Compound 4, half-maximal inhibitory concentration: 9.4 nM
For compound 4 the middle estimate is 2.7-fold (0.43 log units) below the measured one; the range from low to high includes it.
By their numbers in this assay, from the lowest: compound 1; then compounds 3, 2 and 4 (each within the scatter of the next).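

In this assay, replacing chloro with methyl on this aromatic carbon gives a 5.5-fold higher number from compound 1 to compound 4 (0.74 log units; beyond the scatter), so this position is sensitive to the change even though only one heavy atom is exchanged for another. The two groups match on everything counted here, with no ring, no hydrogen-bond donors or acceptors, and no net charge, so these counts alone do not capture what separates them at this position. No measurement shown here explains the step, so the result records the size of the change but not its cause.

Within the data shown here, with the rest of compound 1 held fixed, chloro and methyl are the only two groups compared at this position, so it remains open how others, such as bromo, ethyl or an amine, would behave there. Going by these compounds, it also remains open whether the same swap would produce a step of similar size on a different framework, such as that of compound 3, where the rest of the molecule differs.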